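Replacing the acyl group of a stable amide

A few compounds are considered here, and "the series" means these few. Any claim that something is new, unique, unknown or untested is made for them only; others in the source may bear on it.

In an ADME assay on microsomes from liver (Homo sapiens) for metabolic stability, read by LC-MS, with a stated time of 30 min, tested at 1 uM (on this read-out higher numbers stand for a more stable compound and lower numbers for a less stable compound), compound 1 (`O=C(NCc1ccc(S(=O)(=O)c2ccccc2)cc1)c1cc2ncccc2s1`) gives 81% and stands highest of the two compounds measured. Compound 2 (`O=C(NCc1ccc(S(=O)(=O)c2ccccc2)cc1)c1ccc2cnccc2c1`) gives 31% in this assay and lies lower by a gap beyond the usual scatter. Compound 3 (`O=C(NCc1ccc(S(=O)(=O)c2ccccc2)cc1)c1ccc2nncn2c1`) is still unmeasured. It differs from compound 1 in one place, on a carbonyl carbon (a group of 9 heavy atoms (6 carbon, 3 nitrogen; one five-membered aromatic ring with 3 hetero atoms, one six-membered aromatic ring with 1 hetero atom) in place of a group of 9 heavy atoms (7 carbon, 1 nitrogen, 1 sulfur; one five-membered aromatic ring with 1 hetero atom, one six-membered aromatic ring with 1 hetero atom), on a carbonyl carbon). The six-membered aromatic ring with 1 hetero atom remains, while the five-membered aromatic ring goes from 1 hetero atom to 3 hetero atoms. Within the data shown here, no measured pair shows this change alone, so the size of the step is uncertain. A modest fall is expected in this assay, possibly within the scatter, and the step is estimated as a number 13 percentage points lower from compound 1 to compound 3 (beyond the scatter) for now. Compound 3 is expected at 68% with an estimated range from 42% to 90% for its first measurement.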

Compound 3, percent of the compound remaining: 96%
For compound 3 the middle estimate is 28 percentage points below the measured one, and the stated range ends below it.
By their numbers in this assay, from the lowest: compound 2; then compound 1; then compound 3.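

In this assay, the group on the carbonyl carbon can change its five-membered aromatic ring from 1 hetero atom to 3 hetero atoms without a loss, and the swap gives a number 15 percentage points higher from compound 1 to compound 3 (beyond the scatter) in percent of compound remaining. Among these compounds, this is the first step read at this place, and it shows that the sulfur of the group in compound 1 is not required for a high number here. Among the compounds shown here, nothing measured so far explains the rise.

A single pair cannot separate the loss of the sulfur from the gain in nitrogen atoms, since both changes arrive together in compound 3. It also leaves open how the number would respond to an acyl group carrying an amine or a carboxylic acid at this same carbonyl carbon.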